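This account rests on a few compounds, and the source may have more. Where it says the series, first, only, none or still open, it means among the compounds named here.

The series shares one core, seen in compound 1, `Fc1ccc2nc(-c3cnco3)n(C3CC3)c2c1`, and in compound 2, `Fc1ccc2nc(-c3cncs3)n(C3CC3)c2c1`. In an ADME assay on cells for inhibition of cytochrome P450 11B1, mitochondrial (Homo sapiens), read by HPLC, with a stated time of 60 min (on this read-out lower numbers stand for stronger inhibition and higher numbers for weaker inhibition), compound 1 gives only a limit, > 10000 nM. In this assay compound 2 gives 4520 nM, the one number among the two results shown. For the measured compounds named here, the step of an at least 2.2-fold lower number from compound 1 to compound 2 (0.34 log units; beyond the scatter) is the only measured step, and it rests on (the limit of > 10000 nM in this assay, at which 1 of the 2 values shown sits), so its true size stays open. Compound 3, `Fc1ccc2nc(-c3ccnnc3)n(C3CC3)c2c1`, differs from compound 2 by pyridazin-4-yl in place of 1,3-thiazol-5-yl on an aromatic carbon. This change is not the same as the measured one, which exchanged one five-membered ring for another; here a six-membered ring enters. Going by the values given here, the only guide is that the ring at this position can move the number, as the step from compound 1 to compound 2 shows. Compound 3 is therefore expected to stay near compound 2, with the step of a 1.3-fold lower number from compound 2 to compound 3 (0.11 log units; within the scatter) expected to remain within the scatter. The estimate for compound 3 in this assay is 3500 nM, within 700 nM to 15000 nM.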

Compound 3, half-maximal inhibitory concentration: > 10000 nM
Compound 3 was reported as a limit (the forecaster's own chance of this, stated with the estimate: 25%); middle value at least 2.8-fold (0.45 log units) from the limit.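

Replacing 1,3-thiazol-5-yl with pyridazin-4-yl gives an at least 2.2-fold higher number from compound 2 to compound 3 (0.34 log units; beyond the scatter) in this assay, so a second ring exchange at this place moves the number beyond the scatter, and here the six-membered ring lies on the weaker side. The two rings have the same counts of hetero atoms and hydrogen-bond acceptors, so those counts do not separate them. Compound 3 now ends at a limit, as compound 1 does, so the step between these two cannot be read and the comparison of the three rings rests on a single number and two limits: the limit of > 10000 nM in this assay, at which 2 of the 3 values shown sit.

From the compounds shown here alone, how far compound 1 and compound 3 lie past their limits stays open, as does the true size of both readable steps. Also open, going by these compounds, is whether a six-membered ring with a single ring nitrogen, such as pyridin-3-yl, or a group of another kind at this place, such as an amine or a carboxylic acid, would give a number in this assay on either side of that of compound 2.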